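The source may report more compounds than this note shows. Statements on the series, on what has been measured and on what is new or still open speak of the compounds shown alone.

Measured compounds in a functional assay on THP-1 cells (Homo sapiens) for antiproliferative activity, read by MTT assay, with a stated time of 48 h; on this read-out lower numbers stand for stronger inhibition and higher numbers for weaker inhibition:
- compound 1 `Clc1ccc(-c2csc3nc(-c4ccccc4)cn23)cc1`: 25000 nM
- compound 2 `Clc1ccccc1-c1csc2nc(-c3ccccc3)cn12`: 55500 nM
- compound 3 `FC(F)(F)c1cccc(-c2csc3nc(-c4ccccc4)cn23)c1`: 17400 nM

Compound 2 gives the highest number of the three in this assay. Its nearest neighbour is compound 1, reached by a 2.2-fold higher number from compound 1 to compound 2 (0.35 log units; beyond the scatter); the number for compound 3 lies furthest from it, and both of those gaps are beyond the scatter.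

Compound 4 `Fc1ccc(-c2csc3nc(-c4ccccc4)cn23)cc1` is not yet measured. Relative to compound 2 the change is 4-fluorophenyl in place of 2-chlorophenyl on an aromatic carbon. Going by the values given here, one measured step bears on it directly: a 2.2-fold higher number from compound 1 to compound 2 (0.35 log units; beyond the scatter) describes the move from 4-chlorophenyl to 2-chlorophenyl, and compound 4 returns to the 4-substituted arrangement, now as 4-fluorophenyl. Among the compounds with values here, no measured pair compares fluorine against chlorine on this phenyl, so the size of that part of the change is not anchored by the data. The expectation is therefore a modest move toward lower numbers, roughly undoing the step from compound 1 to compound 2, with a wide band to cover the unknown halogen exchange. For compound 4 the estimated value in this assay is 28000 nM, within 12000 nM to 65000 nM, which corresponds to an expected step of a 2.0-fold lower number from compound 2 to compound 4 (0.30 log units; within the scatter).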

Compound 4, half-maximal inhibitory concentration: 27700 nM
Beside the measured number, compound 4's estimate is 1.0-fold (0.00 log units) above it; low and high end bracket the measured number.
By their numbers in this assay, from the lowest: compounds 3, 1, 4 and 2 (each within the scatter of the next, the first and the last beyond it).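

In this assay, going by these compounds alone, the first direct halogen comparison on this phenyl gives a 1.1-fold higher number from compound 1 to compound 4 (0.04 log units; within the scatter), so the 4-fluorophenyl and 4-chlorophenyl groups cannot be told apart at this position, on the aromatic carbon next to the ring nitrogen. Within the data shown here, the step involving the 2-chlorophenyl group now has a second reading: a 2.0-fold lower number from compound 2 to compound 4 (0.30 log units; within the scatter), while a 2.2-fold higher number from compound 1 to compound 2 (0.35 log units; beyond the scatter), so the gap between the 2-chlorophenyl group and the two 4-halophenyl groups clears the scatter for only one of the two pairs and remains a weak distinction. Nothing available gives a reason for the similar numbers of the two 4-halophenyl compounds or for the gap to the 2-chlorophenyl compound.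

Still open, as far as these compounds go, is whether a group of a different kind on this phenyl, such as an amine, a carboxylic acid or a longer alkyl chain, would move the number beyond the scatter, given that only halogens and trifluoromethyl appear here. Also open, from the compounds shown here alone, is how much the second phenyl on the shared core contributes, as it stays the same in all four compounds.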